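The compounds below may be only part of what the source reports. "The series", "measured", "known", "first", "only" and "open" are said of these compounds alone.

In a functional assay with Oryctolagus cuniculus as the target (on this read-out lower numbers stand for stronger inhibition and higher numbers for weaker inhibition), compound 2 `COc1ccc(-c2nc(C(=O)N(C)C)sc2-c2ccc(OC)cc2)cc1` gives < 100 nM, which is a limit of the assay and not a number. In this assay compound 1 `COc1ccc(-c2nc(N=C(N)N)sc2-c2ccc(OC)cc2)cc1` gives 31000 nM. Going by the values given here, the only measured step, an at least 310-fold lower number from compound 1 to compound 2 (2.49 log units; beyond the scatter), is large and beyond the scatter. It puts a group of 5 heavy atoms in place of a group of 4 heavy atoms (1 carbon, 3 nitrogen; no ring) on an aromatic carbon.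

Compound 3 `COc1ccc(-c2nc(C(=O)N=C(N)N)sc2-c2ccc(OC)cc2)cc1` keeps the carbonyl of compound 2 but changes what it carries: a group of 4 heavy atoms (1 carbon, 3 nitrogen; no ring) in place of a group of 3 heavy atoms (2 carbon, 1 nitrogen; no ring), on a carbonyl carbon. Dimethylamino leaves, and a group with the same count as the one in compound 1 enters, on a carbonyl carbon rather than on an aromatic carbon. The measured step therefore bears only in part. A move to a higher number in this assay is expected, smaller than an at least 310-fold lower number from compound 1 to compound 2 (2.49 log units; beyond the scatter). The expected step is an at least 20-fold higher number from compound 2 to compound 3 (1.30 log units; beyond the scatter). For compound 3 the estimate is 2000 nM, with an expected range of 150 nM to 25000 nM.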

Compound 3, half-maximal inhibitory concentration: > 100 nM
Compound 3 was reported as a limit; the forecaster's own chance of this, stated with the estimate: 15%; the middle value lies beyond the limit too.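

Compound 3 gives a limit of the assay and not a number in this assay: > 100 nM. Compound 2 also gives a limit and not a number: < 100 nM. The new point is that, with the carbonyl kept, the exchange of dimethylamino for the entering group on the carbonyl carbon gives a number no lower from compound 2 to compound 3 (the limit leaves the size open). The step from compound 1 to compound 3 cannot be read.

From the compounds shown here alone, the true values of compound 2 and compound 3 stay open, and with them how much of the gain seen with compound 2 depends on dimethylamino and how much on the carbonyl itself. Also open, going by these compounds, is how diethylamino, a plain amine or a carboxylic acid on this carbonyl carbon would read.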